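Changing the Aryl Group on the Ring Nitrogen: Expected Effect

The source may report more compounds than this note shows. Statements on the series, on what has been measured and on what is new or still open speak of the compounds shown alone.

Compound 1 `Cc1nc(-c2ccc(Cl)cc2)sc1C1SCC(=O)N1c1ccc(F)c(Cl)c1` gives 65.1% in a functional assay on the whole organism (strain Wistar albino) for inhibition, with Rattus norvegicus as the target, read by paw edema, with stated times of 1 h and 4 h, at a dose of 40 mg/kg by the oral route; on this read-out lower numbers stand for less inhibition and higher numbers for more inhibition at the one dose given (going by the name of the read-out).
Compound 2 `Cc1nc(Cc2ccc(Cl)cc2)sc1C1SCC(=O)N1c1ccc(F)c(Cl)c1` gives 68.9% in this assay.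
Compound 3 `COc1ccc(N2C(=O)CSC2c2sc(-c3ccccc3)nc2C)cc1` gives 67.1% in this assay.

All three numbers lie within the usual scatter of one another, so the inhibition in this assay is level among them; compound 3 stands between the other two. Compound 4 `Cc1nc(-c2ccccc2)sc1C1SCC(=O)N1c1ccc(F)c(Cl)c1` has not yet been measured. It differs from compound 3 by 3-chloro-4-fluorophenyl in place of 4-methoxyphenyl on an amide-type nitrogen in a ring. Going by the values given here, the one measured step, a number 3.8 percentage points higher from compound 1 to compound 2 (within the scatter), concerns a change elsewhere in the shared core, so no measured step bears directly on this change. Compound 4 is expected to show a number 1.1 percentage points lower from compound 3 to compound 4 (within the scatter), nothing beyond the scatter, because compound 1 carrying the same entering group gives 65.1%. The estimate for compound 4 is 66%, between 56% and 76%.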

Compound 4, a percentage reported as inhibition, in the whole organism at one dose (the size of the read-out at that dose, not a potency): 28.6%
The estimate for compound 4 lay 37.4 percentage points above the measured number; the measured number lies below the stated range.
By their numbers in this assay, from the lowest: compound 4; then compounds 1, 3 and 2 (each within the scatter of the next).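

Swapping the group on the amide-type nitrogen in a ring is not neutral in this assay: 3-chloro-4-fluorophenyl in place of 4-methoxyphenyl gives a number 38.5 percentage points lower from compound 3 to compound 4 (beyond the scatter). With that same nitrogen group, the chloro of the 4-chlorophenyl also matters, since its loss gives a number 36.5 percentage points lower from compound 1 to compound 4 (beyond the scatter), and phenyl in place of 4-chlorobenzyl gives a number 40.3 percentage points lower from compound 2 to compound 4 (beyond the scatter).

Nothing available explains this drop. Still open, as far as these compounds go, is whether a bromo or a methyl in place of that chloro would keep the inhibition, and how 4-methoxyphenyl on the nitrogen behaves alongside 4-chlorophenyl.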